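Iodo for tert-butyl on the aryl ring of compound 2

The source may report more compounds than this note shows. Statements on the series, on what has been measured and on what is new or still open speak of the compounds shown alone.

Compound 2 `CC(C)(C)c1ccc(-n2nc(-c3ccc(C(F)(F)F)cc3O)nc2-c2ccccc2O)cc1` has been measured in a functional assay on PC-12 cells (Rattus norvegicus) for cytotoxicity, read by MTT assay, with stated times of 2 h and 24 h, tested at 1 uM (on this read-out higher numbers stand for a stronger effect at the one concentration tested and lower numbers for a weaker effect), where compound 2 gives 67.3%. Among the measured compounds shown here, the only other number known comes from compound 1 `CC(C)c1ccc(-n2nc(-c3ccc(C(F)(F)F)cc3O)nc2-c2ccccc2O)cc1`, which in this assay gives 69.7%; the step of a number 2.4 percentage points lower from compound 1 to compound 2 (within the scatter) lies within the scatter, so the two compounds cannot be told apart on this read-out. Compound 3 `Oc1cc(C(F)(F)F)ccc1-c1nc(-c2ccccc2O)n(-c2ccc(I)cc2)n1` has not yet been measured. It differs from compound 2 in a single place: iodo in place of tert-butyl on an aromatic carbon. For the measured compounds named here, the one measured step, from compound 1 to compound 2, alters the same group, by methyl in place of hydrogen on a saturated chain carbon bound to an aromatic carbon and two saturated chain carbons, and it moved the read-out by a number 2.4 percentage points lower from compound 1 to compound 2 (within the scatter), within the scatter. That change is small and only loosely related to exchanging the whole tert-butyl for iodo, so the evidence is thin. With no step beyond the scatter anywhere in the series, the expected step is a number 1.3 percentage points lower from compound 2 to compound 3 (within the scatter), none beyond the scatter. The estimate for compound 3 in this assay is 66%, with a range from 50% to 80%.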

Compound 3, a percentage reported as activity, at one concentration (the size of the read-out at that concentration, not a potency): 70.1%
Compound 3: the middle estimate sits 4.1 percentage points below what was measured; low and high end bracket the measured number.
By their numbers in this assay, from the lowest: compounds 2, 1 and 3 (each within the scatter of the next).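

In this assay, the exchange of tert-butyl for iodo on the aromatic carbon amounts to a number 2.8 percentage points higher from compound 2 to compound 3 (within the scatter), and the exchange of isopropyl for iodo amounts to a number 0.4 percentage points higher from compound 1 to compound 3 (within the scatter). The earlier compounds shown here compared only isopropyl with tert-butyl, whereas this result adds a non-carbon substituent at the same place, and the three compounds still cannot be told apart on this read-out. Nothing available here explains this lack of separation.

Whether an amine, a carboxylic acid or a longer chain at this position would give a number beyond the scatter remains open, since all three groups shown leave this assay within the scatter. The compounds also share one core and were read at a single concentration, so they leave open how the read-out would respond to changes elsewhere on the core or to other concentrations.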